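Swapping Phenoxy for Fluorophenyl on a Weak Oxidase Binder

The compounds below may be only part of what the source reports. "The series", "measured", "known", "first", "only" and "open" are said of these compounds alone.

Three compounds sharing one core were tested in an assay on isolated protein for inhibition of 2-Hydroxyacid oxidase 2 (Homo sapiens), tested at 1 uM; a lower number here means a weaker effect, a higher number a stronger effect of the compound at the concentration tested. Compound 1 `Cc1n[nH]c(C(=O)O)c1Cc1cccc(-c2ccccc2F)c1` gives 5%. Within the data shown here, compound 2 `Cc1n[nH]c(C(=O)O)c1Cc1cccc(C(=O)O)c1` gives 3%; the only one-place step among the measured compounds is a number 2 percentage points lower from compound 1 to compound 2 (within the scatter). Compound 3 `Cc1n[nH]c(C(=O)O)c1Cc1ccccc1Oc1ccccc1` gives 9%, the highest of the three numbers, though its gap to compound 1 and its gap to compound 2 both lie within the scatter, so all three sit together at a weak level.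

Compound 4 `Cc1n[nH]c(C(=O)O)c1Cc1ccccc1-c1ccc(F)cc1` has not yet been measured. It differs from compound 3 in one place: 4-fluorophenyl in place of phenoxy on an aromatic carbon. The new group sits on an aromatic carbon of a six-membered aromatic ring of carbon only, ortho to a large group. Among the measured compounds shown here, no measured step involves this exchange; the single step from compound 1 to compound 2 concerns a different change and was itself within the scatter. For the measured compounds named here, with every number so far weak and no step beyond the scatter, the expected step of a number 2 percentage points lower from compound 3 to compound 4 (within the scatter) is none beyond the scatter. Compound 4 is therefore estimated at 7%, in a range from 0% to 18%.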

Compound 4, a percentage reported as inhibition, at one concentration (the size of the read-out at that concentration, not a potency): 11%
Estimate against measurement, compound 4: 4 percentage points below; measured number inside the range.
By their numbers in this assay, from the lowest: compounds 2, 1, 3 and 4 (each within the scatter of the next).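

In this assay, 4-fluorophenyl in place of phenoxy on this aromatic carbon, ortho to a large group, gives a number 2 percentage points higher from compound 3 to compound 4 (within the scatter) and so shows no change that can be told apart from the scatter. The group that leaves has one hydrogen-bond acceptor and the group that enters has none, yet they have the same count of heavy atoms and the read-out stays at the same weak level, so this exchange gives no sign that the acceptor matters at this position. Nothing available explains the result.

As far as these compounds go, it remains open whether an amine or a nitrile on this carbon would move the read-out beyond the scatter. A plain phenyl there would show whether the fluorine of 4-fluorophenyl counts for anything.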